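Swapping the Aryl Group on a Sulfonamide Nitrogen

The compounds below may be only part of what the source reports. "The series", "measured", "known", "first", "only" and "open" are said of these compounds alone.

Three related sulfonamides have been tested so far in a functional assay on DU-145 cells (Homo sapiens) for inhibition, read by CCK-8 assay, with a stated time of 72 h; on this read-out lower numbers stand for stronger inhibition and higher numbers for weaker inhibition. Compound 1 (`O=C(/C=C/c1cccnc1)NCCCc1ccc(S(=O)(=O)Nc2ccccc2)cc1`) gives > 10000 nM as its result, which is a limit of the assay and not a number. Compound 2 (`O=C(/C=C/c1cccnc1)NCCCCCc1ccc(S(=O)(=O)Nc2ccccc2)cc1`) gives 581 nM in the same test. Compound 3 (`Cc1ccccc1NS(=O)(=O)c1cccc(CCCCCCNC(=O)/C=C/c2cccnc2)c1`) gives 2.9 nM and so holds the lowest number shown. Its nearest neighbour, compound 2, lies well beyond the usual scatter from it.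

The next compound, compound 4 (`CCc1ccc(NS(=O)(=O)c2cccc(CCCCCCNC(=O)/C=C/c3cccnc3)c2)cc1`), has not yet been measured. It differs from compound 3 in one place, with 4-ethylphenyl in place of 2-methylphenyl on a sulfonamide nitrogen. Among the compounds with values here, no measured pair in this set isolates that swap, so the expectation remains loose. With compound 3 at 2.9 nM there seems more room for the number to go up than down, and compound 2 at 581 nM shows how widely values spread among these few compounds. The expected change in this assay is a moderate rise toward weaker inhibition, estimated as a 3.1-fold higher number from compound 3 to compound 4 (0.49 log units; beyond the scatter) and likely only a little beyond the scatter. For compound 4, an estimated 9 nM is expected (range 1.5 nM to 80 nM).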

Compound 4, half-maximal inhibitory concentration: 40.1 nM
Estimate against measurement, compound 4: 4.5-fold (0.65 log units) below; the range from low to high includes it.
By their numbers in this assay, from the lowest: compound 3; then compound 4; then compound 2. At a limit, above all of these: compound 1.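

In this assay, within the data shown here, the aryl group on the sulfonamide nitrogen is the first place in this set where a single change can be read, and the result shows that this position is far from indifferent: putting 4-ethylphenyl in place of 2-methylphenyl gives a 14-fold higher number from compound 3 to compound 4 (1.14 log units; beyond the scatter), a large step. The size of that step stands out against how little the computed comparison separates the two groups, which differ by one carbon and share a six-membered aromatic ring of carbon only, with no hydrogen-bond donors or acceptors and no net charge on either. Nothing among the measurements shown accounts for the step, so it stands as an observation without a reason.

The swap alters both the alkyl group and its place on the ring at once, and the compounds shown do not separate these two changes. Going by these compounds, it also remains open how this nitrogen would respond to an aryl group carrying an amine or a carboxylic acid in place of the ethyl group.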